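Swapping Bromo for Methoxy Under a Cytotoxicity Limit

The compounds below may be only part of what the source reports. "The series", "measured", "known", "first", "only" and "open" are said of these compounds alone.

In an ADME assay on Vero cells (Chlorocebus sabaeus) for cytotoxicity, read by neutral red uptake (a lower number here means that less compound is tolerated, a higher number that more compound is tolerated), compound 2 `O=C1CCC(=O)C1=C/C=C/c1ccc(Br)cc1` gives > 16.3 uM, which is a limit of the assay and not a number. The unsubstituted compound 1 `O=C1CCC(=O)C1=C/C=C/c1ccccc1` gives > 22.4 uM, and this too is a limit. Compound 2 therefore has no exact place on the scale yet. Compound 3 `COc1ccc(/C=C/C=C2C(=O)CCC2=O)cc1` differs from it in one group: methoxy in place of bromo on an aromatic carbon. Going by the values given here, the only measured step that bears on this change is a step that the two limits leave unreadable from compound 1 to compound 2, where bromo takes the place of hydrogen on an aromatic carbon. That step offers no size to carry over, so no change beyond the usual scatter is expected in this assay. The estimated step is a step that the limit leaves unreadable from compound 2 to compound 3. Compound 3 is expected at 25 uM, with an estimated range from 12 uM to 55 uM, and it too may well be reported only as a limit.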

Compound 3, half-maximal toxic concentration: > 19.6 uM
Compound 3 gave a limit, no number; the forecaster's own chance of this, stated with the estimate: 75%; the middle value does not contradict the limit.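

Going by these compounds alone, compound 1, compound 2 and compound 3 each give only a limit in this assay, not a number, and no step among them can be read. The compounds shown leave open where each true value lies and whether bromo or methoxy changes it at all.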